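The source may report more compounds than this note shows. Statements on the series, on what has been measured and on what is new or still open speak of the compounds shown alone.

Measured compounds in a functional assay on MIA PaCa-2 cells (Homo sapiens) for antiproliferative activity, read by MTT assay, with a stated time of 72 h; on this read-out higher numbers stand for an effect only at larger amounts of compound and lower numbers for an effect already at smaller amounts:
compound 1 `CNC(=O)c1cccc(Cn2nc(C)c(NC(=O)c3ccc(COc4ccccc4OC)cc3)c2C)c1` gives 8500 nM
compound 2 `CNC(=O)c1cccc(Cn2nc(C)c(NC(=O)c3ccc(COc4cccc(OC)c4)cc3)c2C)c1` gives 6200 nM
compound 3 `CNC(=O)c1cccc(Cn2nc(C)c(NC(=O)c3ccc(COc4ccccc4Cl)cc3)c2C)c1` gives 6300 nM

All three share one core and differ only in the aryl group on the oxygen on a saturated carbon. Compound 3 stands second highest of the three numbers; its nearest neighbour is compound 2, since the step of a 1.0-fold higher number from compound 2 to compound 3 (0.01 log units; within the scatter) is within the scatter, and the step of a 1.3-fold lower number from compound 1 to compound 3 (0.13 log units; within the scatter) is also within the scatter. Likewise the step of a 1.4-fold lower number from compound 1 to compound 2 (0.14 log units; within the scatter) is within the scatter. On the numbers shown, none of the three compounds can be set apart from the others.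

The next compound, compound 4 `CNC(=O)c1cccc(Cn2nc(C)c(NC(=O)c3ccc(COc4ccc(C(F)(F)F)cc4)cc3)c2C)c1`, follows from compound 3 by one change: 4-(trifluoromethyl)phenyl in place of 2-chlorophenyl on an oxygen on a saturated carbon. Two of the measured steps bear on it, as each also swaps the aryl group on the oxygen on a saturated carbon: the step from compound 2 to compound 3 and the step from compound 1 to compound 2, both within the scatter. On this basis no step beyond the scatter is expected in this assay from compound 3 to compound 4, and the expected step is a 1.0-fold higher number from compound 3 to compound 4 (0.01 log units; within the scatter). Compound 4 is accordingly estimated at 6500 nM in this assay, with a range from 3000 nM to 14000 nM.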

Compound 4, half-maximal effective concentration: 800 nM
Beside the measured number, compound 4's estimate is 8.1-fold (0.91 log units) above it; the whole stated range lies above it.
By their numbers in this assay, from the lowest: compound 4; then compounds 2, 3 and 1 (each within the scatter of the next).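

In this assay, the aryl group on the oxygen on a saturated carbon had produced no step beyond the scatter among compound 1, compound 2 and compound 3, but 4-(trifluoromethyl)phenyl now gives a 7.9-fold lower number from compound 3 to compound 4 (0.90 log units; beyond the scatter) and a 7.8-fold lower number from compound 2 to compound 4 (0.89 log units; beyond the scatter) and an 11-fold lower number from compound 1 to compound 4 (1.03 log units; beyond the scatter) and all of these lie beyond the scatter. This position therefore does respond to the choice of aryl group, with compound 4 holding the lowest number of the set, while 2-methoxyphenyl, 3-methoxyphenyl and 2-chlorophenyl stay within the scatter of one another. Nothing at hand explains why this one aryl group stands apart from the other three.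

The change to compound 4 alters both the substituent and its place on the ring, so the shown compounds cannot tell whether the step follows the trifluoromethyl group or that place, a question that 4-chlorophenyl or 4-methoxyphenyl at this position would address. Also open, as far as these compounds go, is how the series responds to an amine or a carboxylic acid on this aryl group.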